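This account rests on a few compounds, and the source may have more. Where it says the series, first, only, none or still open, it means among the compounds named here.

The measurements come from a functional assay for inhibition, with Homo sapiens as the target; a higher number here means a weaker inhibitor, a lower number a stronger inhibitor. Compound 1, with the structure `CCCc1nc(C)c2c(C(C)C)cnc(Nc3cc[nH]n3)n12`, has been tested there. In this assay compound 1 gives > 48000 nM, which is a limit of the assay rather than a number. Compound 2, `Cc1nc(C)n2c(=O)n(C)ncc12`, also reaches only a limit in this assay, namely > 48000 nM. Compound 3, `CSc1nnc(C)c2c(C)nc(C)n12`, likewise gives in this assay a limit, > 48000 nM. So compound 1 stands nowhere in particular among the three: all that is known is the limit of > 48000 nM in this assay, at which 3 of the 3 values shown sit, with no value that would set one compound apart from another.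

Compound 4, `CCCc1nc(C)c2c(CC)cnc(Nc3cc[nH]n3)n12`, has not yet been measured in this assay. It differs from compound 1 by hydrogen in place of methyl on a saturated chain carbon bound to an aromatic carbon and a saturated chain carbon, that is, a hydrogen in place of a methyl on a saturated chain carbon bound to an aromatic carbon and a saturated chain carbon. Since every measured compound sits at the limit, no step beyond the scatter is expected for this small change; the step from compound 1 to compound 4 is estimated as a step that the limit leaves unreadable from compound 1 to compound 4. Compound 4 is therefore expected to give about 60000 nM, most likely again as a limit, in a range from 20000 nM to 200000 nM.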

Compound 4, half-maximal inhibitory concentration: > 48000 nM
Compound 4: no number, only a limit (the forecaster's own chance of this, stated with the estimate: 85%); the middle value does not contradict the limit.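

Compound 1 and compound 4 both give only a limit in this assay, so the change from isopropyl to ethyl yields no readable step: the limit of > 48000 nM in this assay, at which 4 of the 4 values shown sit. The compounds shown leave open how isopropyl and ethyl compare, and which structures would give an actual number in this assay.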